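The compounds below may be only part of what the source reports. "The series", "measured", "known", "first", "only" and "open" are said of these compounds alone.

Compound 1 `COc1ccc(/C=C/C(=O)Nc2cc3c(Nc4ccc(F)c(Cl)c4)ncnc3cc2O[C@H]2CCOC2)c(OC)c1` carries a 2,4-dimethoxyphenyl group on a double-bonded chain carbon; in a functional assay on PC-3 cells (Homo sapiens) for cytotoxicity, read by MTT assay, with a stated time of 72 h (on this read-out higher numbers stand for weaker inhibition and lower numbers for stronger inhibition), compound 1 gives 2760 nM, the lowest of the two numbers reported. Compound 2 `COc1ccc(/C=C/C(=O)Nc2cc3c(Nc4ccc(F)c(Cl)c4)ncnc3cc2OC)c(OC)c1` gives 38500 nM, and the step of a 14-fold higher number from compound 1 to compound 2 (1.14 log units; beyond the scatter) follows from methyl in place of oxolan-3-yl on an oxygen on an aromatic ring. Compound 3 `COc1cc(/C=C/C(=O)Nc2cc3c(Nc4ccc(F)c(Cl)c4)ncnc3cc2OC)cc(OC)c1` is reported as "not active" (no number reported), with no number. Compound 4 `O=C(/C=C/c1ccc(F)cc1Cl)Nc1cc2c(Nc3ccc(F)c(Cl)c3)ncnc2cc1O[C@H]1CCOC1` differs from compound 1 by 2-chloro-4-fluorophenyl in place of 2,4-dimethoxyphenyl on a double-bonded chain carbon bound to a double-bonded chain carbon. For the measured compounds named here, no measured step touches this part of the molecule, so direction and size of the change cannot be read from the data; compound 3 only shows that altering the substituents of the 2,4-dimethoxyphenyl group can abolish activity. Compound 4 is therefore expected near 3500 nM, within a wide range from 700 nM to 18000 nM. The expected step is a 1.3-fold higher number from compound 1 to compound 4 (0.10 log units; within the scatter).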

Compound 4, half-maximal inhibitory concentration: 7150 nM
For compound 4 the middle estimate is 2.0-fold (0.31 log units) below the measured one, within the range that was stated.
By their numbers in this assay, from the lowest: compound 1; then compound 4; then compound 2.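

In this assay, for the compounds shown here, the change to 2-chloro-4-fluorophenyl gives a 2.6-fold higher number from compound 1 to compound 4 (0.41 log units; beyond the scatter) and is the first step with a number at this place, on a double-bonded chain carbon bound to a double-bonded chain carbon. The entering group has no hydrogen-bond acceptors, yet compound 4 still gives a number, so within this pair the methoxy groups of the 2,4-dimethoxyphenyl group are not needed for a measurable value. The data shown offer no explanation for the size or direction of this step. As far as these compounds go, it remains open how an amine or a carboxylic acid on this phenyl ring would read out. Also open, from the compounds shown here alone, is whether 2-chloro-4-fluorophenyl would give a similar step with methyl in place of oxolan-3-yl on the oxygen.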